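This account rests on a few compounds, and the source may have more. Where it says the series, first, only, none or still open, it means among the compounds named here.

Measured compounds in the cytotoxicity read-out:

Compound 1, `COc1cc(/C=N/NC(=O)c2no[n+]([O-])c2C)ccc1O`: > 400000 nM
Compound 2, `O=C(N/N=C/c1ccc2no[n+]([O-])c2c1)c1cccnc1`: 31000 nM

Of the compounds shown here, two have been tested in an ADME assay on J774.1 cells (Mus musculus) for cytotoxicity, read by MTT assay, with a stated time of 48 h; on this read-out lower numbers stand for stronger inhibition and higher numbers for weaker inhibition. Compound 1 gives > 400000 nM there, which is a limit of the assay and not a number. Compound 2 gives 31000 nM in this assay. So compound 1 stands at the limit of > 400000 nM in this assay, at which 1 of the 2 values shown sits, and no number of its own is known for it.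

Compound 3 `COc1ccc(/C=N/NC(=O)c2no[n+]([O-])c2C)cc1OC` is the next compound to be measured. It differs from compound 1 by methyl in place of hydrogen on an oxygen on an aromatic ring. Among the measured compounds shown here, no pair of measured compounds shows this change on its own, so the expectation for compound 3 rests on compound 1 alone. Compound 1 sits at the limit, and a small change of this kind is expected to move the read-out little, so the step of a number no higher from compound 1 to compound 3 (the limit leaves the size open) is expected to be none beyond the usual scatter, with a good chance that compound 3 is again reported only as a limit. For compound 3 the half-maximal inhibitory concentration in this assay is estimated at 400000 nM, within a range from 100000 nM to 1000000 nM.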

Compound 3, half-maximal inhibitory concentration: > 400000 nM
Compound 3: only a limit was reported; the forecaster's own chance of this, stated with the estimate: 75%; the middle value sits exactly at the limit.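

Compound 1 and compound 3 are each reported only as a limit of the assay, so no step can be read between them: the limit of > 400000 nM in this assay, at which 2 of the 3 values shown sit.

The compounds shown leave open whether going from hydroxy to methoxy on the aromatic ring changes the result in this assay at all, and by how much.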